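Swapping Fluoro for Trifluoromethylsulfanyl on a Quinoline Urea

A few compounds are considered here, and "the series" means these few. Any claim that something is new, unique, unknown or untested is made for them only; others in the source may bear on it.

Compound 1, `Cc1cc(NC(=O)Nc2ccccc2N)c2ccccc2n1`: 300 10^-6 cm/s
Compound 2, `Cc1cc(NC(=O)Nc2ccc(F)cc2)c2ccccc2n1`: 801 10^-6 cm/s

In an ADME assay for permeability, using PAMPA, at pH 7.4 (a lower number here means that the compound crosses the layer more slowly, a higher number that the compound crosses the layer faster), compound 2 stands highest of the two numbers; its nearest neighbour is compound 1, separated by a 2.7-fold higher number from compound 1 to compound 2 (0.43 log units; beyond the scatter). Compound 3, `Cc1cc(NC(=O)Nc2ccc(SC(F)(F)F)cc2)c2ccccc2n1`, differs from compound 2 in one place: (trifluoromethyl)sulfanyl in place of fluoro on an aromatic carbon. Among the measured compounds shown here, the only measured step alters a different part of the molecule, so it bears on this change only loosely; no measured step exchanges one substituent for another on that ring. With so little to go on, the expected change in this assay is small, none beyond the scatter. Compound 3 is therefore estimated at 700 10^-6 cm/s, within a range from 350 10^-6 cm/s to 1400 10^-6 cm/s. That estimate means an expected step of a 1.1-fold lower number from compound 2 to compound 3 (0.06 log units; within the scatter).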

Compound 3, apparent permeability: 206 10^-6 cm/s
Compound 3: the middle estimate sits 3.4-fold (0.53 log units) above what was measured; the measured number lies below the stated range.
By their numbers in this assay, from the lowest: compounds 3 and 1 (each within the scatter of the next); then compound 2.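

In this assay, the ring carbon para to a large group turns out to matter: (trifluoromethyl)sulfanyl in place of fluoro gives a 3.9-fold lower number from compound 2 to compound 3 (0.59 log units; beyond the scatter), the first substituent exchange seen at this position. The earlier step changed the same ring, but not through a swap at this carbon alone. Nothing available explains the drop. On these data alone, whether a chlorine atom, a methoxy group or an amine on that carbon would give a number closer to that of compound 2 stays open, as does whether the same swap would give a similar step on another core.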